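Chloro in Place of Cyano at the Assay Limit

This account rests on a few compounds, and the source may have more. Where it says the series, first, only, none or still open, it means among the compounds named here.

Compound 3 `C/C(=C\c1cc(-c2ccc(C#N)cc2)cs1)C(N)=O` stands at a limit of a functional assay on T-24 cells (Homo sapiens) for cytotoxicity, read by CCK-8 assay, with a stated time of 24 h; a lower number here means a stronger inhibitor, a higher number a weaker inhibitor: it shows only > 50000 nM, which is a limit and not a number. Compound 2 `C/C(=C\c1cc(-c2ccc(C)cc2)cs1)C(N)=O` likewise returns only the limit > 50000 nM. Compound 1 `C/C(=C\c1cc(-c2ccc(C)nc2)co1)C(N)=O` also gives only the limit > 50000 nM. For the measured compounds named here, the one step that could bear on the change, a step that the two limits leave unreadable from compound 2 to compound 3, cannot be read because of the limit of > 50000 nM in this assay, at which 3 of the 3 values shown sit. Compound 4 `C/C(=C\c1cc(-c2ccc(Cl)cc2)cs1)C(N)=O` differs from compound 3 by chloro in place of cyano on an aromatic carbon. Going by the values given here, with every value in this assay sitting at the limit, no measured step gives a direction or a size, so compound 4 is expected to remain at the limit as well. The estimate for compound 4 is therefore 50000 nM, in the range 20000 nM to 100000 nM. The step of a number no higher from compound 3 to compound 4 (the limit leaves the size open) is expected to be essentially none.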

Compound 4, half-maximal inhibitory concentration: > 50000 nM
Compound 4: a limit, no number; the forecaster's own chance of this, stated with the estimate: 85%; the middle value lies on the limit itself.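

The steps from compound 2 and from compound 3 to compound 4 cannot be read, because: the limit of > 50000 nM in this assay, at which 4 of the 4 values shown sit.
The compounds shown leave open how methyl, cyano and chloro compare in this assay and whether any of them gives a readable number.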